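This account rests on a few compounds, and the source may have more. Where it says the series, first, only, none or still open, it means among the compounds named here.

The series shares one core; compound 1 `CNc1nc(N)nc2c1ncn2/C=C1/CC1(CO)CO` carries methylamino on an aromatic carbon, compound 2 `CCOc1nc(N)nc2c1ncn2/C=C1/CC1(CO)CO` carries ethoxy at that carbon, and compound 3 `Nc1nc(NC2CC2)c2ncn(/C=C3/CC3(CO)CO)c2n1` carries cyclopropylamino there. In an ADME assay on HFF cells (Homo sapiens) for cytotoxicity, with a stated time of 8 days (on this read-out higher numbers stand for lower toxicity in this test and lower numbers for higher toxicity in this test), compound 1 gives 265000 nM. Compound 2 gives > 300000 nM in this assay, which is a limit of the assay and not a number. Compound 3 gives > 300000 nM in this assay, again a limit. Two of the three values thus sit at the same ceiling, (the limit of > 300000 nM in this assay, at which 2 of the 3 values shown sit), and compound 2 stands at that ceiling rather than at a measured point. The measured steps are thin: an at least 1.1-fold higher number from compound 1 to compound 2 (0.05 log units; that floor lies within the scatter), an at least 1.1-fold higher number from compound 1 to compound 3 (0.05 log units; that floor lies within the scatter), and a step that the two limits leave unreadable from compound 2 to compound 3. Compound 4 `CCCCCOc1nc(N)nc2c1ncn2/C=C1/CC1(CO)CO` is the next member: propyl in place of hydrogen on a saturated chain carbon, two bonds along the chain from an oxygen on an aromatic ring. Going by the values given here, none of the measured steps alters an alkoxy chain, so no step bears directly on this change; they show only that each substituent tried so far on that aromatic carbon leaves the read-out at or near the ceiling of this assay. For compound 4 a modest step towards higher toxicity is expected, an at least 1.6-fold lower number from compound 2 to compound 4 (0.22 log units; that floor lies within the scatter), with a real chance that the ceiling is reported once more. Compound 4 is estimated at 180000 nM, between 50000 nM and 300000 nM.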

Compound 4, half-maximal cytotoxic concentration: 259000 nM
Estimate against measurement, compound 4: 1.4-fold (0.16 log units) below; low and high end bracket the measured number.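

In this assay the first change inside the alkoxy chain, ethoxy to pentyloxy, yields a number rather than a ceiling value, yet the readable steps stay small: an at least 1.1-fold lower number from compound 2 to compound 4 (0.06 log units; that floor lies within the scatter), and likewise an at least 1.1-fold lower number from compound 3 to compound 4 (0.06 log units; that floor lies within the scatter). Pentyloxy and methylamino on this aromatic carbon cannot be told apart, with a 1.0-fold lower number from compound 1 to compound 4 (0.01 log units; within the scatter) as the step between them. Adding propyl at this chain carbon therefore gives no step that can be read as beyond the scatter, and the true size of that step stays unknown because compound 2 gives only a limit and not a number: the limit of > 300000 nM in this assay, at which 2 of the 4 values shown sit.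

As far as these compounds go, whether a longer chain than pentyloxy, or an amine or a carboxylic acid at the end of the pentyloxy chain, would carry the number clear of the scatter stays open. Also open, from the compounds shown here alone, is whether pentylamino at this aromatic carbon would match pentyloxy, and how the same change would read in any test other than this one.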